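Amine oxidase B series: methoxybenzyl to nitrobenzyl step

A few compounds are considered here, and "the series" means these few. Any claim that something is new, unique, unknown or untested is made for them only; others in the source may bear on it.

Measured so far in an assay on isolated protein for inhibition of Amine oxidase [flavin-containing] B (Homo sapiens), read by fluorescence, with stated times of 15 min and 20 min; a lower number here means a stronger inhibitor, a higher number a weaker inhibitor:
- compound 1 `CC(C)(C)c1cc(CCC(=O)NCCC2CCN(Cc3ccccc3)CC2)cc(C(C)(C)C)c1O` gives 46900 nM
- compound 2 `CC(C)(C)c1cc(/C=C/C(=O)NC2CCN(Cc3ccccc3)CC2)cc(C(C)(C)C)c1O` gives 33500 nM
- compound 3 `COc1ccc(CN2CCC(CCNC(=O)/C=C/c3cc(C(C)(C)C)c(O)c(C(C)(C)C)c3)CC2)cc1` gives 6700 nM

Compound 3 has the lowest number of the three in this assay. Its nearest neighbour on the numbers is compound 2, whose value is higher by a margin beyond the usual scatter; compound 1 is further still, also beyond the scatter. For the measured compounds named here, no pair of these three differs in one place only, so none of these gaps can be read as a single-change step.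

Compound 4 `CC(C)(C)c1cc(/C=C/C(=O)NCCC2CCN(Cc3cccc([N+](=O)[O-])c3)CC2)cc(C(C)(C)C)c1O` is not yet measured. It is built from compound 3 by one change:

3-nitrophenyl in place of 4-methoxyphenyl on a saturated chain carbon bound to an amine nitrogen in a ring

Going by the values given here, no measured pair shows this change, and no measured compound carries the 3-nitrophenyl group, so there is nothing in the present numbers to anchor the size or direction of the step in this assay. The expectation is therefore a cautious one: compound 4 is estimated to come out near compound 3, with a mild weakening as the more likely side, the step of a 1.8-fold higher number from compound 3 to compound 4 (0.25 log units; within the scatter) being expected to fall close to or just beyond the scatter. For compound 4 the estimate in this assay is 12000 nM, with a range from 4000 nM to 35000 nM.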

Compound 4, half-maximal inhibitory concentration: 12500 nM
Compound 4: the middle estimate sits 1.0-fold (0.02 log units) below what was measured, and the stated range covers the measured number.
By their numbers in this assay, from the lowest: compounds 3 and 4 (each within the scatter of the next); then compounds 2 and 1 (each within the scatter of the next).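

In this assay, for the compounds shown here, 3-nitrophenyl in place of 4-methoxyphenyl on a saturated chain carbon bound to an amine nitrogen in a ring gives a 1.9-fold higher number from compound 3 to compound 4 (0.27 log units; within the scatter), the first step that can be read as a single change, and it lies within the usual scatter. At this position the two groups therefore cannot be told apart in this assay, although the entering group has more heavy atoms and more hydrogen-bond acceptors, and the exchange replaces the methoxy group with a nitro group under a different numbered name. No supporting measurement bears on why the two groups read alike.

The compounds shown leave open whether this tolerance extends to other groups at the same position, such as an unsubstituted phenyl or a phenyl carrying an amine or a carboxylic acid, and whether the identity of the substituent and its numbered place would each matter if varied alone. Compounds 1 and 2 differ from compounds 3 and 4 in more than one place, so steps involving them cannot be read, and the contribution of the remainder of the structure stays unresolved.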